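Sulfonyl in place of carbonyl at the aromatic nitrogen

A few compounds are considered here, and "the series" means these few. Any claim that something is new, unique, unknown or untested is made for them only; others in the source may bear on it.

Compound 1 `O=C(Nc1cccc(/C=C/C(=O)c2nc3ccccc3[nH]2)c1)c1cccc(Br)c1` and compound 2 `Cc1ccccc1C(=O)Nc1cccc(/C=C/C(=O)c2nc3ccccc3[nH]2)c1` share a core and differ only in the group on the carbonyl carbon. In a functional assay on MCF7 cells (Homo sapiens) for antiproliferative activity, read by MTT assay, with a stated time of 48 h (a higher number here means a weaker inhibitor, a lower number a stronger inhibitor), compound 1 gives 5210 nM, and compound 2 gives 5870 nM; the step of a 1.1-fold higher number from compound 1 to compound 2 (0.05 log units; within the scatter) does not separate them. Compound 2 thus stands at one end of the two-number range, but within the scatter of compound 1.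

Compound 3 `Cc1ccccc1S(=O)(=O)Nc1cccc(/C=C/C(=O)c2nc3ccccc3[nH]2)c1` is the next compound to be measured. Relative to compound 2 the change is (2-methylphenyl)sulfonyl in place of (2-methylphenyl)carbonyl on a nitrogen on an aromatic ring. Within the data shown here, no measured step touches this linker: the only step in hand, a 1.1-fold higher number from compound 1 to compound 2 (0.05 log units; within the scatter), varies the ring on the carbonyl carbon and sits within the scatter. With nothing to anchor a direction, compound 3 is expected to show no step beyond the scatter, a 1.0-fold higher number from compound 2 to compound 3 (0.01 log units; within the scatter). Compound 3 is therefore estimated at 6000 nM, with a range from 2000 nM to 18000 nM in this assay.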

Compound 3, half-maximal inhibitory concentration: 4130 nM
Compound 3: middle estimate off by 1.5-fold (0.16 log units), on the high side; the measured number falls inside the stated range.
By their numbers in this assay, from the lowest: compounds 3, 1 and 2 (each within the scatter of the next).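

In this assay, among these compounds, the linker on the aromatic nitrogen is varied here for the first time. With the 2-methylphenyl ring kept, sulfonyl in place of carbonyl gives the step (a 1.4-fold lower number from compound 2 to compound 3 (0.15 log units; within the scatter)), so this exchange does not separate the two linkers. The wider exchange at the same nitrogen, (2-methylphenyl)sulfonyl in place of (3-bromophenyl)carbonyl, gives the step (a 1.3-fold lower number from compound 1 to compound 3 (0.10 log units; within the scatter)), so both linkers are accommodated at this position and the three compounds remain unseparated; no supporting data bear on this reading.

Still open, as far as these compounds go, is whether a methylene linker on the same nitrogen, or an amine or a carboxylic acid on the 2-methylphenyl ring, would move the number beyond the scatter. Also open, from the compounds shown here alone, is whether the sulfonyl linker reads the same when it carries a 3-bromophenyl ring.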